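A Second Swap on the Amide-Type Nitrogen

This account rests on a few compounds, and the source may have more. Where it says the series, first, only, none or still open, it means among the compounds named here.

In a functional assay on MDA-MB-435 cells (Homo sapiens) for cytotoxicity, read by MTT assay, with a stated time of 72 h (a higher number here means a weaker inhibitor, a lower number a stronger inhibitor), compound 1 `CN(C)c1ccc(CNC(=O)c2nc(Br)c3cccnc3c2N[C@H]2CC[C@H](N)CC2)cc1` gives 4000 nM. Compound 2 `C[C@H](NC(=O)c1nc(Br)c2cccnc2c1N[C@H]1CC[C@H](N)CC1)c1ccc(F)cc1` gives > 10000 nM, which is a limit of the assay and not a number. Among the measured compounds shown here, the one measured step at this place is an at least 2.5-fold higher number from compound 1 to compound 2 (0.39 log units; beyond the scatter). From the compounds shown here alone, it lies beyond the scatter, but its true size stays open. Compound 3 `N[C@H]1CC[C@H](Nc2c(C(=O)NCc3cccc(C(F)(F)F)c3)nc(Br)c3cccnc23)CC1` keeps the shared core and changes the same place: 3-(trifluoromethyl)benzyl in place of 1-(4-fluorophenyl)ethyl on an amide-type nitrogen. In words, 3-(trifluoromethyl)benzyl stands in place of 1-(4-fluorophenyl)ethyl on an amide-type nitrogen. Compound 1, a benzyl case at 4000 nM, shows that a group here can give a real number, so a modest move toward lower numbers is expected in this assay. The expected step is an at least 1.6-fold lower number from compound 2 to compound 3 (0.22 log units; that floor lies within the scatter), and it may still end at the limit. Compound 3 is estimated at 6000 nM, with an expected range of 2500 nM to 10000 nM.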

Compound 3, half-maximal inhibitory concentration: 4200 nM
Estimate against measurement, compound 3: 1.4-fold (0.15 log units) above; the range from low to high includes it.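

In this assay, putting 3-(trifluoromethyl)benzyl in place of 1-(4-fluorophenyl)ethyl gives an at least 2.3-fold lower number from compound 2 to compound 3 (0.37 log units; beyond the scatter), so a second group on this amide-type nitrogen yields a real number. The two benzyl groups are not told apart, as 3-(trifluoromethyl)benzyl in place of 4-(dimethylamino)benzyl gives a 1.1-fold higher number from compound 1 to compound 3 (0.02 log units; within the scatter), so two different ring substituents read alike here. The true size of the step stays open, since compound 2 holds a limit and not a number: the limit of > 10000 nM in this assay, at which 1 of the 3 values shown sits.

The group of compound 2 differs from the other two in both its defined stereocentre and its fluorine, so the shown compounds cannot separate these features. Also open, from the compounds shown here alone, is how a plain benzyl, a longer chain such as 2-phenylethyl, or a benzyl carrying a carboxylic acid would read at this nitrogen.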